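Two Measured Compounds and an Expected Flat Step

A few compounds are considered here, and "the series" means these few. Any claim that something is new, unique, unknown or untested is made for them only; others in the source may bear on it.

compound 1 `CC[C@H](C)[C@@H](NCC(=O)NNC(=O)COc1ccc(-c2nc3ccccc3s2)cc1OC)C(=O)O` gives 1790 nM
compound 2 `CCOC(=O)[C@H](CS)N(CC(=O)NNC(=O)COc1ccc(-c2nc3ccccc3s2)cc1OC)C(C)=O` gives 1890 nM

Among the measured compounds shown here, in a functional assay on MCF7 cells (Homo sapiens) for inhibition, read by MTT assay, with a stated time of 3 days (a lower number here means a stronger inhibitor, a higher number a weaker inhibitor), compound 2 gives 1890 nM as its value, which cannot be told apart from the only other measurement. Compound 3 `CCOC(=O)[C@H](CS(=O)(=O)O)NCC(=O)NNC(=O)COc1ccc(-c2nc3ccccc3s2)cc1OC` departs from compound 2 by (1-(ethoxycarbonyl)-2-sulfoethyl)amino in place of acetyl(1-(ethoxycarbonyl)-2-sulfanylethyl)amino on a saturated chain carbon bound to a carbonyl carbon and so has (1-(ethoxycarbonyl)-2-sulfoethyl)amino in place of acetyl(1-(ethoxycarbonyl)-2-sulfanylethyl)amino on a saturated chain carbon bound to a carbonyl carbon. For the measured compounds named here, the one measured step at this place, a 1.1-fold higher number from compound 1 to compound 2 (0.02 log units; within the scatter) in this assay, is small, so no step beyond the scatter is expected, although no measured compound carries the sulfo group. The expected change is a 1.1-fold higher number from compound 2 to compound 3 (0.02 log units; within the scatter) and remains an estimate. The estimated value for compound 3 is 2000 nM (900 nM to 4500 nM).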

Compound 3, half-maximal inhibitory concentration: 1990 nM
Beside the measured number, compound 3's estimate is 1.0-fold (0.00 log units) above it, and the stated range covers the measured number.
By their numbers in this assay, from the lowest: compounds 1, 2 and 3 (each within the scatter of the next).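

In this assay the step of a 1.1-fold higher number from compound 2 to compound 3 (0.02 log units; within the scatter) and the step of a 1.1-fold higher number from compound 1 to compound 3 (0.05 log units; within the scatter) both stay within the scatter, so three differently built groups on a saturated chain carbon bound to a carbonyl carbon cannot be told apart. The earlier pair showed this only for the sulfanyl compound with its acetyl on the nitrogen. Compound 3 extends it to a sulfo group with no acetyl there, and its ethoxycarbonyl group is shared with compound 2, while 1-carboxy-2-methylbutyl in compound 1 carries neither group.

The compounds shown leave open whether a hydroxyl group or a primary amide in place of the sulfo group would stay within the scatter too, or whether some other group at this place would move the number at all. No measurement offered here explains why these steps are so small.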